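The source may hold more compounds than are shown below. What is called first, only, known or untested is meant among the compounds shown, and "the series" means these compounds.

Measured in an ADME assay on J774.A1 cells (Mus musculus) for cytotoxicity, read by MTT assay, with a stated time of 48 h; a lower number here means that less compound is tolerated, a higher number that more compound is tolerated:
- compound 1 `COC(=O)c1c([N+](=O)[O-])noc1-c1ccc(Cl)cc1Cl`: 19700 nM
- compound 2 `O=C(NCc1ccccc1)c1c([N+](=O)[O-])noc1-c1ccc(Cl)cc1`: "not determined" (no result reported)
- compound 3 `O=C(NCc1ccccc1)c1c([N+](=O)[O-])noc1-c1ccc(Cl)cc1Cl`: "not determined" (no result reported)

Compound 3 has no number to stand on: no result was reported for it in this assay, and the same holds for compound 2. Only compound 1, which carries no benzyl amide at all, gives a figure, at 19700 nM.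

The next compound keeps everything in compound 3 except the group on the amide side. Compound 4 `O=C(NCc1cccc(Cl)c1Cl)c1c([N+](=O)[O-])noc1-c1ccc(Cl)cc1Cl` has 2,3-dichlorophenyl in place of phenyl on a saturated chain carbon bound to an amide-type nitrogen, which can also be read as benzyl to 2,3-dichlorobenzyl: 2,3-dichlorophenyl in place of phenyl on a saturated chain carbon bound to an amide-type nitrogen.

Within the data shown here, no measured pair in this small set shows what such a change does, so the size of the step from compound 3 cannot be read from the data. Among the measured compounds shown here, with no starting number, the only anchor is compound 1 at 19700 nM. Compound 4 is expected to fall close to that figure, with no shift beyond the usual scatter and at most a slight lean toward less compound being tolerated. This is a weak expectation, resting on a single value from a compound with a different amide-side group.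

For compound 4 the half-maximal cytotoxic concentration is estimated at 16000 nM, with an expected range from 4000 nM to 60000 nM.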

Compound 4, half-maximal cytotoxic concentration: 81800 nM
Estimate against measurement, compound 4: 5.1-fold (0.71 log units) below; measured number outside the range, above it.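

In this assay, among these compounds, compound 4 gives 81800 nM while compound 3 carries no number, so no step between compound 3 and compound 4 can be read. The compounds shown leave open what the change from benzyl to 2,3-dichlorobenzyl does to the tolerated concentration. Nothing shown here speaks to the reason for the result.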